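The source may report more compounds than this note shows. Statements on the series, on what has been measured and on what is new or still open speak of the compounds shown alone.

Series notes. Of the compounds shown here, two of the shared core have been measured in an assay on membranes from CHO cells for displacement of a labelled ligand from adenosine receptor A1 (Homo sapiens), read by scintillation counting, with a stated time of 60 min, tested at 1 uM; on this read-out higher numbers stand for more inhibition at the one concentration tested (going by the name of the read-out) and lower numbers for less inhibition. Compound 1 `CC1=C(C(=O)SC(C)C)C(c2cccs2)NC(=O)N1` gives 1%. Compound 2 `CC1=C(C(=O)OC2CCCC2)C(c2ccoc2)NC(=O)N1` gives 6%. Compound 2 stands highest of the two numbers, but its nearest neighbour, compound 1, lies only within the usual scatter of the measurement, so the two values cannot be told apart and neither number is called the higher. Both readings sit close to the floor of this assay.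

The step under consideration runs from compound 2 to compound 3 `CC1=C(C(=O)OC2CCCC2)C(c2cccs2)NC(=O)N1`. The change: thiophen-2-yl in place of furan-3-yl on a saturated ring carbon. The cyclopentyl ester of compound 2 is kept; the ring on the saturated carbon is exchanged for the ring that compound 1 carries. For the measured compounds named here, no directly comparable step between measured compounds is available, so the size of the step is not anchored.

Given that compound 1 gives 1% and compound 2 gives 6%, no movement beyond the scatter is expected, and the step of a number 1 percentage points lower from compound 2 to compound 3 (within the scatter) is estimated as essentially flat. For compound 3 the expected inhibition in this assay is 5%, with a range from -8% to 20%.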

Compound 3, a percentage reported as inhibition, at one concentration (the size of the read-out at that concentration, not a potency): 9%
For compound 3 the middle estimate is 4 percentage points below the measured one; the measured number falls inside the stated range.
By their numbers in this assay, from the lowest: compounds 1, 2 and 3 (each within the scatter of the next).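

In this assay, thiophen-2-yl in place of furan-3-yl on the saturated ring carbon, with the cyclopentyl ester kept, gives a number 3 percentage points higher from compound 2 to compound 3 (within the scatter), so this exchange of one five-membered aromatic ring for another does not separate the two compounds at this position. The series also now has a one-place comparison at the carbonyl carbon: with thiophen-2-yl held constant, cyclopentyloxy in place of isopropylsulfanyl gives a number 8 percentage points higher from compound 1 to compound 3 (within the scatter), and neither of the two changes moves the reading beyond the scatter. No supporting measurement bears on this result.

The compounds shown do not tell whether this position responds to anything other than these two rings, such as a phenyl ring carrying an amine, or whether a carboxylic acid in place of the ester on the carbonyl carbon would move the reading beyond the scatter. With single-concentration readings that lie this close together, they also leave open how these compounds would differ in potency, and whether the methyl group on the shared core has any influence on the reading.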